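Methanesulfonamido for Cyano on Compound 3

The source may report more compounds than this note shows. Statements on the series, on what has been measured and on what is new or still open speak of the compounds shown alone.

In a functional assay on MC-38 cells (Mus musculus) for antiproliferative activity (a lower number here means a stronger inhibitor, a higher number a weaker inhibitor), compound 1 (`COc1ccc(S(=O)(=O)Nc2cccc3cc[nH]c23)cc1`) gives 1.5 ug/mL and compound 2 (`N#Cc1ccc(S(=O)(=O)Nc2cccc3cc[nH]c23)cc1`) gives 1.8 ug/mL. Compound 3 (`N#Cc1ccc(S(=O)(=O)Nc2cccc3c(C#N)c[nH]c23)cc1`) has the lowest number of the three at 0.12 ug/mL, and the step to it is a 15-fold lower number from compound 2 to compound 3 (1.18 log units; beyond the scatter). Compound 4 (`CS(=O)(=O)Nc1ccc(S(=O)(=O)Nc2cccc3c(C#N)c[nH]c23)cc1`) carries methanesulfonamido in place of cyano on an aromatic carbon, para to a large group: methanesulfonamido in place of cyano on an aromatic carbon. The closest measured precedent is a swap at that same place, a 1.2-fold higher number from compound 1 to compound 2 (0.08 log units; within the scatter), whereas the large step from cyano in place of hydrogen lies elsewhere. Methanesulfonamido itself has not been measured in this series. The expected step is a 1.7-fold higher number from compound 3 to compound 4 (0.22 log units; within the scatter), with no change beyond the scatter. Compound 4 is estimated at 0.2 ug/mL, within an expected range of 0.06 ug/mL to 0.7 ug/mL.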

Compound 4, half-maximal inhibitory concentration: 1.2 ug/mL
For compound 4 the middle estimate is 6.0-fold (0.78 log units) below the measured one; measured number outside the range, above it.
By their numbers in this assay, from the lowest: compound 3; then compounds 4, 1 and 2 (each within the scatter of the next).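

In this assay, methanesulfonamido in place of cyano gives a 10-fold higher number from compound 3 to compound 4 (1.00 log units; beyond the scatter) and so shows that this place, para to a large group, is not indifferent to what it carries. The earlier change there, cyano for methoxy, gave only a 1.2-fold higher number from compound 1 to compound 2 (0.08 log units; within the scatter) and was read without the second cyano of compound 3. Nothing available explains the rise in compound 4. On these data alone, whether an amine or a carboxylic acid at this place would keep the number of compound 3 stays open, as does how methanesulfonamido behaves without that second cyano.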